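Compound 1 to compound 3: exchange on the chain

This account rests on a few compounds, and the source may have more. Where it says the series, first, only, none or still open, it means among the compounds named here.

Compound 1 `C=CS(=O)(=O)NC/C=C/c1cc(OC)cc(O)c1C(=O)OCC1CCCCC1`: 27.4%
Compound 2 `C=CS(=O)(=O)NC/C=C/c1cc(OC)cc(O)c1C(=O)OCc1ccc(F)cc1`: 52%

In a functional assay on K562 cells (Homo sapiens) for inhibition, read by luminescence, with a stated time of 72 h, tested at 5 uM (on this read-out higher numbers stand for more inhibition of growth at the one concentration tested and lower numbers for less inhibition of growth), compound 1 gives 27.4%, the lower of the two numbers. Within the data shown here, the only measured step is a number 24.6 percentage points higher from compound 1 to compound 2 (beyond the scatter), with 4-fluorophenyl in place of cyclohexyl.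

Compound 3 `COc1cc(O)c(C(=O)OCC2CCCCC2)c(/C=C/CN2C(=O)C=CC2=O)c1` keeps the cyclohexyl of compound 1 and differs at one other place, a saturated chain carbon bound to a double-bonded chain carbon: a group of 7 heavy atoms (4 carbon, 1 nitrogen, 2 oxygen; one five-membered non-aromatic ring with 1 hetero atom) in place of a group of 6 heavy atoms (2 carbon, 1 nitrogen, 2 oxygen, 1 sulfur; no ring), on a saturated chain carbon bound to a double-bonded chain carbon. The (vinylsulfonyl)amino group leaves there. Among the measured compounds shown here, no measured step touches this place, so the one step available serves only as a guide to size and gives no direction. A change no larger than that modest step is expected, and none beyond the scatter is the likeliest outcome in this assay. The estimated value for compound 3 is 33%, with an expected range of 12% to 58%. This estimate amounts to an expected a number 5.6 percentage points higher from compound 1 to compound 3 (within the scatter).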

Compound 3, percent growth inhibition at one concentration: 85.1%
Estimate against measurement, compound 3: 52.1 percentage points below; measured number above the stated range.
By their numbers in this assay, from the lowest: compound 1; then compound 2; then compound 3.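

In this assay, a number 57.7 percentage points higher from compound 1 to compound 3 (beyond the scatter), so the place on a saturated chain carbon bound to a double-bonded chain carbon, which the earlier pair left unchanged, has a large effect on the read-out. With the cyclohexyl held constant, this step isolates the exchange of the (vinylsulfonyl)amino group for the group containing one five-membered non-aromatic ring. No supporting data explain the size of this step.

Still open, from the compounds shown here alone, is whether 4-fluorophenyl in place of cyclohexyl would add to this exchange when the two changes are combined in one compound. Also open, going by these compounds, is whether the response depends on the whole entering group or on the double bond within its ring, a question that the saturated five-membered ring or a simple amine at this place could address.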